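Amide swap from compound 3 to compound 4

A few compounds are considered here, and "the series" means these few. Any claim that something is new, unique, unknown or untested is made for them only; others in the source may bear on it.

Measured in a functional assay on DLD-1 cells (Homo sapiens) for antiproliferative activity, read by sulforhodamine B assay, with a stated time of 48 h; a higher number here means a weaker inhibitor, a lower number a stronger inhibitor:
Compound 1 `COc1ccc(-c2oc3c(OC)c(OC)cc(OCCCC(=O)NCc4ccccn4)c3c(=O)c2O)cc1`: > 40000 nM, a limit
Compound 2 `COc1ccc(-c2oc3c(OC)c(OC)cc(OCCCC(=O)N4CCN(C)CC4)c3c(=O)c2O)cc1`: > 40000 nM, a limit
Compound 3 `CCCCN(C)C(=O)CCCCOc1cc(OC)c(OC)c2oc(-c3ccc(OC)cc3)c(O)c(=O)c12`: 17400 nM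

For the measured compounds named here, compound 3 is the only one with an actual number, while compound 1 and compound 2 stand at the limit of > 40000 nM in this assay, at which 2 of the 3 values shown sit. Compound 4 `COc1ccc(-c2oc3c(OC)c(OC)cc(OCCCCC(=O)NCc4ccccn4)c3c(=O)c2O)cc1` changes the group on a carbonyl carbon: ((pyridin-2-yl)methyl)amino in place of butyl(methyl)amino on a carbonyl carbon. The closest measured evidence is an at least 2.2-fold lower number from compound 1 to compound 3 (0.36 log units; beyond the scatter), where the ((pyridin-2-yl)methyl)carbamoyl group leaves, although the chain also differs. The step of an at least 2.2-fold lower number from compound 2 to compound 3 (0.36 log units; beyond the scatter) points the same way, but a step that the two limits leave unreadable from compound 1 to compound 2 adds nothing. Bringing that group back should therefore raise the number in this assay, and the expected step is a 2.1-fold higher number from compound 3 to compound 4 (0.32 log units; beyond the scatter). Compound 4 is estimated at 36000 nM, with an expected range of 15000 nM to 80000 nM.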

Compound 4, half-maximal inhibitory concentration: > 40000 nM
Compound 4 ended at the assay's limit (the forecaster's own chance of this, stated with the estimate: 55%); middle value at least 1.1-fold (0.04 log units) away from the limit.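

In this assay, placing ((pyridin-2-yl)methyl)amino in place of butyl(methyl)amino on the carbonyl carbon gives an at least 2.2-fold higher number from compound 3 to compound 4 (0.36 log units; beyond the scatter) with the chain unchanged, whereas the earlier comparison of compound 1 with compound 3 also changed the chain. Compound 4 gives only a limit, so the step is a minimum: the limit of > 40000 nM in this assay, at which 3 of the 4 values shown sit. The steps from compound 1 and compound 2 to compound 4 cannot be read, as both ends of each are limits.

Going by these compounds, how far compound 4 lies past its limit stays open. Also open, on these data alone, is whether a dibutylamino or piperidin-1-yl group on this carbonyl carbon, or a longer chain, would give a lower number than compound 3.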